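This account rests on a few compounds, and the source may have more. Where it says the series, first, only, none or still open, it means among the compounds named here.

Measured compounds:
compound 1, `CC[C@@H]1C(=O)N(C)c2cnc(-n3ccc4cc(C(N)=O)ccc43)nc2N1C1CCCC1`: 28.5 nM
compound 2, `CCCNC(=O)c1ccc2c(ccn2-c2ncc3c(n2)N(c2ccn(C)n2)C(CC)C(=O)N3C)c1`: 207 nM

Compound 1, `CC[C@@H]1C(=O)N(C)c2cnc(-n3ccc4cc(C(N)=O)ccc43)nc2N1C1CCCC1`, stands as the stronger of the two measured compounds in an assay for inhibition of serine/threonine-protein kinase PLK2 (Homo sapiens), read by FRET and Z'-LYTE, with a stated time of 1 h (a higher number here means a weaker inhibitor, a lower number a stronger inhibitor), where compound 1 gives 28.5 nM. Compound 2, `CCCNC(=O)c1ccc2c(ccn2-c2ncc3c(n2)N(c2ccn(C)n2)C(CC)C(=O)N3C)c1`, gives 207 nM in this assay, a gap to compound 1 that lies beyond the usual scatter. Compound 2 differs from compound 1 in more than one place, so its two values show only the combined outcome of those changes and not the weight of any one of them.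

Compound 3, `CCCNC(=O)c1ccc2c(ccn2-c2ncc3c(n2)N(C2CCCC2)[C@H](CC)C(=O)N3C)c1`, keeps the cyclopentyl group of compound 1 and carries a single change: propyl in place of hydrogen on an amide-type nitrogen. Among the compounds with values here, no pair of measured compounds differs by this change alone, so the size of the step cannot be read from the data. Compound 2 shows that an alkylated amide on this core still inhibits, but it does not isolate the propyl alone. The step of a 1.8-fold higher number from compound 1 to compound 3 (0.24 log units; within the scatter) is expected to be small, a modest weakening at most, within the range of ordinary scatter or just beyond it. Compound 3 is estimated at 50 nM, with a range from 15 nM to 170 nM.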

Compound 3, half-maximal inhibitory concentration: 11.4 nM
Compound 3: middle estimate off by 4.4-fold (0.64 log units), on the high side, and the stated range ends above it.
By their numbers in this assay, from the lowest: compound 3; then compound 1; then compound 2.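

In this assay, putting propyl in place of hydrogen on the amide-type nitrogen gives a 2.5-fold lower number from compound 1 to compound 3 (0.40 log units; beyond the scatter) and so takes the carbamoyl group of compound 1 to a propylcarbamoyl group with a modest gain in inhibition rather than a loss. The earlier compounds shown here showed only that a propyl-bearing amide could still inhibit, with other differences mixed in; this single-change pair gives the direction and size of the step itself, with the cyclopentyl group and the rest of the core of compound 1 held the same. Nothing measured here bears on why the number falls with this change.

The compounds shown leave open whether a shorter chain such as methyl or ethyl, a longer chain such as butyl, or a chain ending in an amine or a hydroxyl group on this nitrogen would match or exceed propyl. They also leave open what a cyclopropyl ring or a second alkyl group at this nitrogen would do, and whether the step from hydrogen to propyl would hold on cores carrying something other than cyclopentyl.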